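This account rests on a few compounds, and the source may have more. Where it says the series, first, only, none or still open, it means among the compounds named here.

Working notes on the series. Among the measured compounds shown here, the core shared by all members is that of compound 1 `CCCCCCCCc1ccc(OCC(=O)Cn2nnc(C)n2)cc1`, which in an ADME assay on S9 fraction from liver (Rattus norvegicus) for metabolic stability, read by LC-MS, using NADPH, with a stated time of 30 min (a lower number here means that less of the compound is left, a higher number that more of the compound is left), does not give a number: its value of < 5% is a limit of the assay, and the limit of < 5% in this assay, at which 1 of the 2 values shown sits, is the only evidence on that point. Compound 2 `CCCCCCCCc1ccc(OCC(=O)Cn2nnnc2SC)cc1` gives a measured figure in this assay, namely 21%, the only number shown in the series so far. For the measured compounds named here, the measured step of a number at least 16 percentage points higher from compound 1 to compound 2 (beyond the scatter) is the single step in hand.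

Compound 3 `CCCCCCCCc1ccc(OCC(=O)Cn2nnnc2-c2ccc(C(=O)O)cc2)cc1` has not yet been tested. It differs from compound 2 in one place: 4-carboxyphenyl in place of methylsulfanyl on an aromatic carbon. Going by the values given here, no measured step covers the 4-carboxyphenyl group or a change on this aromatic carbon; the only step known concerns the tetrazole ring itself and its attachment, so it bears on compound 3 only as a reference point for compound 2. With nothing to anchor the direction, the expectation for compound 3 in this assay is a step of a number 9 percentage points higher from compound 2 to compound 3 (within the scatter) from compound 2. The estimate for compound 3 is 30%, with a range from 8% to 65%.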

Compound 3, percent of the compound remaining: 6%
Compound 3: the middle estimate sits 24 percentage points above what was measured; measured number below the stated range.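

The earlier step changed the ring and its attachment together. Here only the group on the aromatic carbon of the five-membered aromatic ring with 4 nitrogen changes, and that alone moves the read-out in this assay, with a number 15 percentage points lower from compound 2 to compound 3 (beyond the scatter), so this position is sensitive to what it carries and, of the two groups seen there, methylsulfanyl leaves more of the compound. The result also shows that the gain seen with compound 2 does not carry over to every group at this position, and the step has a practical side, as compound 3 leaves little of the scale free for reading further losses at this position: the limit of < 5% in this assay, at which 1 of the 3 values shown sits.

Among the compounds shown here, the single step swaps a small sulfur-bearing group for a larger group holding both a benzene ring and a carboxylic acid, so it cannot say which of the two parts goes with the lower number. On these data alone, a plain phenyl, a methyl ester of the acid or an amine at this position would separate these parts, and whether any group here does better than methylsulfanyl stays open.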